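Chloro for methyl on the cinnamamide of compound 1

The source may hold more compounds than are shown below. What is called first, only, known or untested is meant among the compounds shown, and "the series" means these compounds.

Measured compounds:
compound 1, `Cc1ccc(/C=C/C(=O)Nc2ccc3nc(N4CCC(O)(C5CC5)CC4)nc(C)c3c2)cc1`, 344 nM
compound 2, `Cc1nc(NCCNS(C)(=O)=O)nc2ccc(NC(=O)/C=C/c3ccc(OC(F)(F)F)cc3)cc12`, 169 nM
compound 3, `Cc1nc(N2CCC(O)CC2)nc2ccc(NC(=O)/C=C/c3ccc(Cl)cc3)cc12`, 107 nM

Of the compounds shown here, three sharing one core have been measured in an assay on CHO-K1 cells for displacement of a labelled ligand from melanin-concentrating hormone receptor 1 (Homo sapiens), read by scintillation proximity assay, with a stated time of 2 h; a higher number here means a weaker inhibitor, a lower number a stronger inhibitor. Compound 1 stands at the highest of the three numbers, so it is the weakest inhibitor of the set; compound 2 gives 169 nM, and compound 3 gives 107 nM, and both of these gaps to compound 1 lie beyond the scatter. Compound 4, `C/C(=C\C(=O)Nc1ccc2nc(N3CCC(O)(C4CC4)CC3)nc(C)c2c1)c1ccc(Cl)cc1`, has not yet been measured. It differs from compound 1 in one place: 2-(4-chlorophenyl)prop-1-en-1-yl in place of 2-(4-methylphenyl)ethenyl on a carbonyl carbon. Going by the values given here, no pair of measured compounds differs in a single place, so no clean step is available to lean on. Compound 3, which carries a chloro on its aryl ring, sits lowest of the three, but it also differs from compound 1 in the piperidine part, so that comparison is mixed. The step from compound 1 to compound 4 is expected to be a modest lowering of the number, a 1.7-fold lower number from compound 1 to compound 4 (0.24 log units; within the scatter). Compound 4 is thus estimated at 200 nM, with a range from 70 nM to 600 nM.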

Compound 4, half-maximal inhibitory concentration: 532 nM
For compound 4 the middle estimate is 2.7-fold (0.42 log units) below the measured one, and the stated range covers the measured number.
By their numbers in this assay, from the lowest: compounds 3 and 2 (each within the scatter of the next); then compounds 1 and 4 (each within the scatter of the next).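

In this assay, going by these compounds alone, the first step between compounds differing in one place reads a 1.5-fold higher number from compound 1 to compound 4 (0.19 log units; within the scatter) and so, on a carbonyl carbon whose other neighbour is an amide-type nitrogen, 2-(4-chlorophenyl)prop-1-en-1-yl and 2-(4-methylphenyl)ethenyl cannot be told apart. The two groups share an aromatic ring of carbon only and a double bond outside it, and neither carries a hydrogen-bond donor or acceptor, so this position accepts the larger, chlorine-bearing group without a change that exceeds the scatter. What lies behind this result cannot be said from the data at hand.

The step joins the chlorine with the extra methyl on the double bond, and the compounds shown do not separate the two. From the compounds shown here alone, how this position would respond to a carboxylic acid, an amine or a longer chain on the aromatic ring remains open.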